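The source may report more compounds than this note shows. Statements on the series, on what has been measured and on what is new or still open speak of the compounds shown alone.

Three compounds have been measured in a functional assay on UO-31 cells (Homo sapiens) for cytotoxicity, read by sulforhodamine B assay, with a stated time of 48 h, tested at 0.1 uM; a lower number here means a stronger effect, a higher number a weaker effect of the compound at the concentration tested:

Compound 1, `COc1ccc(-c2cc(/C=C/C(=O)c3ccc(N)cc3)[nH]n2)cc1`, gives 82%.
Compound 2, `COc1ccc(-c2cc(/C=C/C(=O)c3ccc(N)cc3)[nH]n2)cc1OC`, gives 99%.
Compound 3, `COc1cc(C(=O)/C=C/c2cc(-c3cc(OC)c(OC)c(OC)c3)n[nH]2)cc(OC)c1OC`, gives 90%.

The change hydrogen in place of methoxy on an aromatic carbon brought a number 17 percentage points lower from compound 2 to compound 1 (beyond the scatter). Compound 4, `COc1ccc(-c2cc(/C=C/C(=O)c3cc(OC)c(OC)c(OC)c3)[nH]n2)cc1OC`, is not yet measured; it differs from compound 3 by hydrogen in place of methoxy on an aromatic carbon. The surroundings are not identical: in compound 4 the place is also meta to a methoxy group, which the place in compound 1 is not, so this is the same kind of change rather than the same change. How the core of compound 2 differs from the core of compound 3 is not broken down here.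

A step of about the same size is expected, a number 12 percentage points lower from compound 3 to compound 4 (beyond the scatter), resting on the earlier step of a number 17 percentage points lower from compound 2 to compound 1 (beyond the scatter). For compound 4 the expected value is therefore 78%, estimated to fall between 65% and 92%.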

Compound 4, a percentage reported as activity, at one concentration (the size of the read-out at that concentration, not a potency): 82%
For compound 4 the middle estimate is 4 percentage points below the measured one, and the stated range covers the measured number.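

In this assay, putting hydrogen in place of methoxy on the newer core gives a number 8 percentage points lower from compound 3 to compound 4 (within the scatter). Set beside the same change on the earlier core, the two steps cannot be told apart: the same change on two cores in this assay, a number 17 percentage points lower (beyond the scatter) from compound 2 to compound 1 and a number 8 percentage points lower (within the scatter) from compound 3 to compound 4, 9 percentage points apart, within the scatter of two such steps. The numbers therefore fit a change that carries over between these two cores, but they do not prove it: only the earlier step stands clear of the scatter, and two cores tested at a single concentration make a thin basis.

The compounds shown leave open what other groups at this place would do, such as a hydroxyl, a fluorine or a longer ethoxy chain. They also leave open whether the change would carry over to any further core.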